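Trading a chlorobenzyl arm for a short alkyne

The compounds below may be only part of what the source reports. "The series", "measured", "known", "first", "only" and "open" are said of these compounds alone.

Going by the values given here, compound 3 `O=C1c2ccccc2N(Cc2ccccc2Cl)S(=O)(=O)N1Cc1ccccc1` gives in a functional assay on MRC5 cells (Homo sapiens) (a higher number here means that more compound is tolerated, a lower number that less compound is tolerated), a value of 60000 nM, the only plain number among the three compounds measured so far. Compound 1 `O=C1c2ccccc2N(Cc2ccc([N+](=O)[O-])cc2)S(=O)(=O)N1Cc1ccccc1` reaches only the limit of > 59000 nM. Compound 2 `O=C1c2ccccc2N(Cc2ccccc2-c2ccccc2)S(=O)(=O)N1Cc1ccccc1` likewise stops at the limit of > 55000 nM. The step that the limit leaves unreadable from compound 1 to compound 3 and the step that the limit leaves unreadable from compound 2 to compound 3 therefore cannot be sized. Compound 4 `C#CCCN1c2ccccc2C(=O)N(Cc2ccccc2)S1(=O)=O` differs from compound 3 by propargyl in place of 2-chlorophenyl on a saturated chain carbon bound to a sulfonamide nitrogen in a ring. Among the compounds with values here, none of the measured steps bears on this change, and both neighbours of compound 3 sit at limits. The step of no change at the digits printed from compound 3 to compound 4 (within the scatter) is expected to stay within the scatter. Compound 4 is therefore expected to give about 60000 nM in this assay, with a likely range from 30000 nM to 120000 nM.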

Compound 4, half-maximal cytotoxic concentration: 77000 nM
The estimate for compound 4 lay 1.3-fold (0.11 log units) below the measured number, and the stated range covers the measured number.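

Replacing the 2-chlorobenzyl arm with but-3-yn-1-yl, a small open chain with no ring, gives a 1.3-fold higher number from compound 3 to compound 4 (0.11 log units; within the scatter). In this assay, an aromatic ring on this saturated chain carbon is therefore not required for compound 4 to give a plain number that matches compound 3 within the scatter. The step from compound 1 cannot be read, because compound 1 stands at a limit: the limit of > 59000 nM in this assay, at which 1 of the 4 values shown sits. Still open, on these data alone, is whether an amine or a carboxylic acid at this position would leave the number unchanged. A longer chain ending in a hydroxyl group is equally untested by the compounds shown.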